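The source may report more compounds than this note shows. Statements on the series, on what has been measured and on what is new or still open speak of the compounds shown alone.

Working notes on the series. Compound 1 `COc1ccc(/C=C/C(=O)c2cccc(I)c2)cc1` is tested in an ADME assay on Vero cells (Chlorocebus sabaeus) for cytotoxicity, read by resazurin assay, with a stated time of 72 h; a lower number here means that less compound is tolerated, a higher number that more compound is tolerated. In this assay compound 1 returns only a limit, > 100000 nM, and not a number. Compound 2 `CN(C)c1ccc(/C=C/C(=O)c2ccc(-c3ccccc3)cc2)cc1` has no single number in this assay; its entry reads "not determined" (no result reported). Compound 3 `CC(C)(C)c1ccc(C(=O)/C=C/c2ccc([N+](=O)[O-])s2)cc1` likewise reaches only a limit in this assay, namely > 100000 nM. Among the compounds with values here, compound 3 therefore stands at the limit of > 100000 nM in this assay, at which 2 of the 3 values shown sit; nothing beyond that limit is known for it, and no step between two measured compounds is available to lean on. Compound 4 `CSc1ccc(C(=O)/C=C/c2ccc([N+](=O)[O-])s2)cc1` has not yet been measured in this assay. It differs from compound 3 by methylsulfanyl in place of tert-butyl on an aromatic carbon. Within the data shown here, with no measured step to set a size, no change beyond the usual scatter is expected in this assay on going from compound 3 to compound 4, and the most likely outcome is that compound 4 again returns only a limit rather than a number. The expected step is a number no higher from compound 3 to compound 4 (the limit leaves the size open). Compound 4 is estimated at 100000 nM in this assay, with an expected range from 30000 nM to 300000 nM.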

Compound 4, half-maximal cytotoxic concentration: > 100000 nM
Compound 4 ended at the assay's limit; the forecaster's own chance of this, stated with the estimate: 70%; the middle value sits exactly at the limit.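

Within the data shown here, compound 3 and compound 4 both return only a limit in this assay, so no step between them can be read. The compounds shown leave open whether any of them would give an actual number in this assay, and whether methylsulfanyl in place of tert-butyl on an aromatic carbon changes the read-out at all.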